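Swapping dichlorophenyl for dimethylphenyl on the unfluorinated core

The compounds below may be only part of what the source reports. "The series", "measured", "known", "first", "only" and "open" are said of these compounds alone.

Compound 3 `Clc1cccc(N2CCN(CCCCNc3nc(NCc4ccco4)c4ccccc4n3)CC2)c1Cl` is measured in a functional assay on HT-29 cells (Homo sapiens) for cytotoxicity, read by MTT assay, with a stated time of 2 days, tested at 10 uM (on this read-out higher numbers stand for more inhibition at the one concentration tested (going by the name of the read-out) and lower numbers for less inhibition), where compound 3 gives 94.8%. Among the three figures recorded it stands at the bottom, although compound 2 `Cc1cccc(N2CCN(CCCCNc3nc(NCc4ccco4)c4cc(F)ccc4n3)CC2)c1C` gives 96.1% and compound 1 `Fc1ccc2nc(NCCCCN3CCN(c4cccc(Cl)c4Cl)CC3)nc(NCc3ccco3)c2c1` gives 96.3%, both within the scatter of compound 3. Compound 4 `Cc1cccc(N2CCN(CCCCNc3nc(NCc4ccco4)c4ccccc4n3)CC2)c1C` differs from compound 3 by 2,3-dimethylphenyl in place of 2,3-dichlorophenyl on an amine nitrogen in a ring. The same exchange has already been seen once, on the fluorinated core, where a number 0.2 percentage points lower from compound 1 to compound 2 (within the scatter). For the measured compounds named here, the only other step recorded, a number 1.5 percentage points lower from compound 1 to compound 3 (within the scatter), concerns a different position. On that basis the change is expected to produce no shift beyond the scatter, so compound 4 is estimated to give 94.5%, within a range from 88% to 99%, which corresponds to an expected step of a number 0.3 percentage points lower from compound 3 to compound 4 (within the scatter).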

Compound 4, a percentage reported as inhibition, at one concentration (the size of the read-out at that concentration, not a potency): 94.2%
For compound 4 the middle estimate is 0.3 percentage points above the measured one; the range from low to high includes it.
By their numbers in this assay, from the lowest: compounds 4, 3, 2 and 1 (each within the scatter of the next).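

In this assay, the exchange of 2,3-dichlorophenyl for 2,3-dimethylphenyl, with a number 0.6 percentage points lower from compound 3 to compound 4 (within the scatter), now reads the same on the unfluorinated core as on the fluorinated one: the same change on two cores in this assay, a number 0.2 percentage points lower (within the scatter) from compound 1 to compound 2 and a number 0.6 percentage points lower (within the scatter) from compound 3 to compound 4, 0.4 percentage points apart, within the scatter of two such steps. Hydrogen in place of fluoro also gains a second reading, a number 1.9 percentage points lower from compound 2 to compound 4 (within the scatter), and it too agrees across the two cores: the same change on two cores in this assay, a number 1.5 percentage points lower (within the scatter) from compound 1 to compound 3 and a number 1.9 percentage points lower (within the scatter) from compound 2 to compound 4, 0.4 percentage points apart, within the scatter of two such steps. Neither change separates the four compounds beyond the scatter.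

From the compounds shown here alone, what a pyridine or a carboxylic acid-bearing phenyl would give on that amine nitrogen stays open. With a single concentration, any difference in potency among these compounds also stays open.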